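This account rests on a few compounds, and the source may have more. Where it says the series, first, only, none or still open, it means among the compounds named here.

In a functional assay on PC-3 cells (Homo sapiens) for antiproliferative activity, read by sulforhodamine B assay, with a stated time of 48 h (on this read-out higher numbers stand for weaker inhibition and lower numbers for stronger inhibition), the three measured compounds give:

Compound 1 `C[C@H]1N=C2C[C@H]3C[C@H](C3(C)C)[C@@]2(C)OC1=O`: 42000 nM
Compound 2 `CC1(C)[C@@H]2CC3=N[C@@H](CCC(=O)O)C(=O)O[C@@]3(C)[C@H]1C2`: 42000 nM
Compound 3 `CC1(C)[C@H]2CC3=N[C@H](CCC(=O)O)C(=O)O[C@]3(C)[C@@H]1C2`: 38000 nM

Compound 3 holds the lowest of the three numbers, yet both of its neighbours sit within the scatter: a 1.1-fold lower number from compound 1 to compound 3 (0.04 log units; within the scatter), and a 1.1-fold lower number from compound 2 to compound 3 (0.04 log units; within the scatter), a step between mirror images (the fact that compounds 2 and 3 differ only in the configuration as drawn). Compound 4 `CC1(C)[C@H]2CC3=NCC(=O)O[C@]3(C)[C@@H]1C2` takes the acid chain away: hydrogen in place of 2-carboxyethyl on a saturated ring carbon. Among the measured compounds shown here, the only measured step that touches a chain of this kind, that from compound 1 to compound 3, stayed within the scatter, so no step beyond the scatter is expected here: a 1.1-fold higher number from compound 3 to compound 4 (0.02 log units; within the scatter). Compound 4 is therefore estimated at 40000 nM, with a range from 18000 nM to 90000 nM.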

Compound 4, half-maximal inhibitory concentration: > 300000 nM
Compound 4 was reported as a limit; the forecaster's own chance of this, stated with the estimate: 15%; middle value at least 7.5-fold (0.87 log units) away from the limit.
By their numbers in this assay, from the lowest: compounds 3, 1 and 2 (each within the scatter of the next). At a limit, above all of these: compound 4.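

In this assay compound 4 gives > 300000 nM, which is a limit of the assay and not a number. Leaving only hydrogen on this saturated ring carbon is the first change here to move the result beyond the scatter: an at least 7.8-fold higher number from compound 3 to compound 4 (0.89 log units; beyond the scatter), and an at least 7.1-fold higher number from compound 1 to compound 4 (0.85 log units; beyond the scatter). The earlier compounds shown here showed only that methyl and 2-carboxyethyl are interchangeable here; compound 4 shows that having no such group at all is not tolerated. Still open, going by these compounds, is whether a group as small as methyl is the least this position needs, and whether an amine or a hydroxymethyl group on this carbon would serve as well.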